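The source may hold more compounds than are shown below. What is called first, only, known or untested is meant among the compounds shown, and "the series" means these compounds.

Measured compounds:

Compound 1, `COc1cc(/C=C/C2CC=CC(=O)O2)cc(OC)c1`, gives 8.8 uM.
Compound 2, `COc1cc(/C=C/C2CC=CC(=O)O2)cc(OC)c1OC`, gives 21.6 uM.
Compound 3, `COc1cc(/C=C/C2CC=CC(=O)N2)cc(OC)c1`, gives 212 uM.

These three compounds were tested in an ADME assay on HaCaT cells (Homo sapiens) for inhibition, read by sulforhodamine B assay, with a stated time of 48 h; a higher number here means a weaker inhibitor of growth, a lower number a stronger inhibitor of growth. Compound 1 sits lowest of the three. Compound 2 differs from it by a single change, (methoxy in place of hydrogen on an aromatic carbon), and this produced a 2.5-fold higher number from compound 1 to compound 2 (0.39 log units; beyond the scatter). Compound 3 stands highest of the three measured compounds; its number lies above that of compound 2 and above that of compound 1, and both of these gaps are beyond the scatter. The difference between the core of compound 1 and the core of compound 3 is not broken down here.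

Compound 4, `COc1cc(/C=C/C2CC=CC(=O)N2)cc(OC)c1OC`, has not yet been measured in this assay. It relates to compound 3 as compound 2 relates to compound 1: the change is methoxy in place of hydrogen on an aromatic carbon, the same change at the same kind of place, made on the core of compound 3 instead of the core of compound 1. Among the compounds shown this change occurs twice in all, and only one instance has a measured outcome.

The expectation for compound 4 rests on compound 3 and on the earlier step. Starting from compound 3 and its value 212 uM, the step is expected to be a 2.1-fold higher number from compound 3 to compound 4 (0.33 log units; beyond the scatter), roughly in line with a 2.5-fold higher number from compound 1 to compound 2 (0.39 log units; beyond the scatter), though a single precedent on a different core leaves the direction and size uncertain. Compound 4 is therefore estimated at 450 uM, within a range from 180 uM to 1200 uM.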

Compound 4, concentration for growth inhibition (reported as GI): > 864 uM
Compound 4 ended at the assay's limit; the forecaster's own chance of this, stated with the estimate: 25%; middle value at least 1.9-fold (0.28 log units) away from the limit.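

In this assay compound 4 gives > 864 uM, which is a limit of the assay and not a number. Methoxy in place of hydrogen on an aromatic carbon gives an at least 4.0-fold higher number from compound 3 to compound 4 (0.61 log units; beyond the scatter), the same direction as a 2.5-fold higher number from compound 1 to compound 2 (0.39 log units; beyond the scatter), so across these two pairs the direction of the change carries from the core of compound 1 to the core of compound 3, while the two cores compared with this methoxy present in both give an at least 40-fold higher number from compound 2 to compound 4 (1.60 log units; beyond the scatter). Two pairs show no general rule, and the size of the change on the second core stays unsettled, so it cannot be said whether the change is larger there or about the same: the same change on two cores in this assay, a 2.5-fold higher number (0.39 log units; beyond the scatter) from compound 1 to compound 2 and an at least 4.0-fold higher number (0.61 log units; beyond the scatter) from compound 3 to compound 4; the limit leaves it open whether they differ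

The compounds shown leave open where the number for compound 4 truly lies, and whether the same change would keep its direction on any third core. They also leave open whether a different group on that aromatic carbon, such as a hydroxyl or a fluorine, would move the number in the same direction on both cores.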